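Thiophene ring attachment on the shared ribose core

This account rests on a few compounds, and the source may have more. Where it says the series, first, only, none or still open, it means among the compounds named here.

Compound 1 `O=c1[nH]cnc2c1c(-c1ccoc1)cn2[C@@H]1O[C@H](CO)[C@@H](O)[C@H]1O` carries furan-3-yl on the shared core; in a functional assay on HCT-116 cells (Homo sapiens), read by MTT assay, with a stated time of 72 h (a lower number here means a stronger inhibitor, a higher number a weaker inhibitor), compound 1 gives 10300 nM. Compound 2 `O=c1[nH]cnc2c1c(-c1cccs1)cn2[C@@H]1O[C@H](CO)[C@@H](O)[C@H]1O` carries thiophen-2-yl in the same place. In this assay compound 2 reaches only the limit of > 20000 nM, so no number is known for it. Compound 3 `Cc1nc(N)c2c(-c3ccccc3)cn([C@@H]3O[C@H](CO)[C@@H](O)[C@H]3O)c2n1`, with a different core and phenyl on the five-membered ring, also sits at a limit in this assay, namely > 100000 nM. Among the measured compounds shown here, the one step measured on the shared core is an at least 1.9-fold higher number from compound 1 to compound 2 (0.28 log units; that floor lies within the scatter), and its floor lies within the scatter.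

Compound 4 `O=c1[nH]cnc2c1c(-c1ccsc1)cn2[C@@H]1O[C@H](CO)[C@@H](O)[C@H]1O` differs from compound 2 by thiophen-3-yl in place of thiophen-2-yl on an aromatic carbon. For the measured compounds named here, no measured step moves the same ring from one attachment to another; the only step that bears on it, an at least 1.9-fold higher number from compound 1 to compound 2 (0.28 log units; that floor lies within the scatter), exchanges one five-membered ring for another and is not resolved beyond the scatter. No step beyond the scatter is therefore expected in this assay, and a second limit is likely. For compound 4 the expected value in this assay is 25000 nM, between 8000 nM and 80000 nM. The expected step is a step that the limit leaves unreadable from compound 2 to compound 4.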

Compound 4, half-maximal inhibitory concentration: > 20000 nM
Compound 4 was reported as a limit; the forecaster's own chance of this, stated with the estimate: 60%; the middle value lies beyond the limit too.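

In this assay compound 4 sits at a limit, the same one as compound 2, so the move from thiophen-2-yl to thiophen-3-yl gives a step that cannot be read, and neither attachment of the thiophene yields a number at this place: the limit of > 20000 nM in this assay, at which 2 of the 4 values shown sit.

Against furan-3-yl the reading is an at least 1.9-fold higher number from compound 1 to compound 4 (0.28 log units; that floor lies within the scatter), so thiophen-3-yl, like thiophen-2-yl, is not shown to differ from furan-3-yl beyond the scatter. Among the compounds shown on the shared core, only compound 1 has a number, at 10300 nM.

Going by these compounds, whether the true values of compound 2 and compound 4 differ from each other or from that of compound 1 stays open. Also open, on these data alone, is how an aminomethyl group, a carboxylic acid or a longer alkyl chain at this place on the shared core would read in this assay.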